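A few compounds are considered here, and "the series" means these few. Any claim that something is new, unique, unknown or untested is made for them only; others in the source may bear on it.

Compound 3 `Cn1c(=O)c(C(=O)Nc2ccc(Oc3ccncc3-c3cccnc3)c(F)c2)nn(-c2ccc(Cl)cc2)c1=O` gives 1600 nM in a functional assay on MKN-45 cells (Homo sapiens) for cytotoxicity, read by MTT assay, with a stated time of 72 h (a higher number here means a weaker inhibitor, a lower number a stronger inhibitor), the highest number among the three measured compounds; compound 1 `Fc1cc(Nc2cc(Nc3ccc(Cl)cc3)ncn2)ccc1Oc1ccncc1-c1cccnc1` gives 240 nM and compound 2 `Fc1cc(Nc2cc(Nc3cccc(Cl)c3)ncn2)ccc1Oc1ccncc1-c1cccnc1` gives 30 nM. Compound 4 `COc1ccc(-n2nc(C(=O)Nc3ccc(Oc4ccncc4-c4cccnc4)c(F)c3)c(=O)n(C)c2=O)c(OC)c1` differs from compound 3 in one place: 2,4-dimethoxyphenyl in place of 4-chlorophenyl on an aromatic nitrogen. Among the measured compounds shown here, the only measured step between neighbours, an 8.0-fold lower number from compound 1 to compound 2 (0.90 log units; beyond the scatter), moved the chlorine on a phenyl attached to a nitrogen of a different core, so it is at most a loose guide; no measured pair shows a chlorophenyl swapped for a dimethoxyphenyl on the core of compound 3. The step of no change at the digits printed from compound 3 to compound 4 (within the scatter) is therefore expected to be none beyond the scatter, with wide uncertainty. Compound 4 is expected to give 1600 nM in this assay, estimated between 400 nM and 6400 nM.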

Compound 4, half-maximal inhibitory concentration: 2820 nM
Compound 4: middle estimate off by 1.8-fold (0.25 log units), on the low side, and the stated range covers the measured number.
By their numbers in this assay, from the lowest: compound 2; then compound 1; then compounds 3 and 4 (each within the scatter of the next).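

Putting 2,4-dimethoxyphenyl in place of 4-chlorophenyl on the aromatic nitrogen in this assay gives a 1.8-fold higher number from compound 3 to compound 4 (0.25 log units; within the scatter) and so leaves the two compounds indistinguishable. On this core, the position therefore tolerates losing the chlorine and gaining more heavy atoms and hydrogen-bond acceptors, which the earlier step on a different core could not show. No measurement here explains this tolerance. From the compounds shown here alone, whether a plain phenyl or a phenyl carrying an amine or a carboxylic acid would fit equally well stays open, as does the contribution of each methoxy group alone.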